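The compounds below may be only part of what the source reports. "The series", "measured", "known", "first", "only" and "open" are said of these compounds alone.

Working notes on the series, read in a functional assay on MM1.S cells (Homo sapiens) for inhibition, with a stated time of 72 h; on this read-out lower numbers stand for stronger inhibition and higher numbers for weaker inhibition. Compound 1 `O=C(NO)c1ccc(CN(C2CC2)S(=O)(=O)c2cc(F)c(F)c(F)c2F)cc1` gives 480 nM, compound 2 `CC(C)CN(Cc1ccc(C(=O)NO)cc1)S(=O)(=O)c1cc(F)c(F)c(F)c1F` gives 690 nM and compound 3 `COCCN(Cc1ccc(C(=O)NO)cc1)S(=O)(=O)c1cc(F)c(F)c(F)c1F` gives 710 nM, so compound 3 stands within the scatter of both others. The next compound is compound 4 `O=C(NO)c1ccc(CN(C2CCCC2)S(=O)(=O)c2cc(F)c(F)c(F)c2F)cc1`, with this change: cyclopentyl in place of 2-methoxyethyl on a sulfonamide nitrogen. In words, cyclopentyl replaces 2-methoxyethyl on a sulfonamide nitrogen. The measured steps at that nitrogen are small: a 1.4-fold higher number from compound 1 to compound 2 (0.16 log units; within the scatter), a 1.5-fold higher number from compound 1 to compound 3 (0.17 log units; within the scatter) and a 1.0-fold higher number from compound 2 to compound 3 (0.01 log units; within the scatter). None of them lies beyond the scatter, and none is therefore expected in this assay here. The estimated step, a 1.3-fold lower number from compound 3 to compound 4 (0.11 log units; within the scatter), stays within the scatter. For compound 4 the expected value is 550 nM, with an estimated range of 250 nM to 1200 nM.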

Compound 4, half-maximal inhibitory concentration: 3300 nM
Beside the measured number, compound 4's estimate is 6.0-fold (0.78 log units) below it, and the stated range ends below it.
By their numbers in this assay, from the lowest: compounds 1, 2 and 3 (each within the scatter of the next); then compound 4.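

In this assay, among these compounds, the cyclopentyl group on the sulfonamide nitrogen gives a 4.6-fold higher number from compound 3 to compound 4 (0.67 log units; beyond the scatter) and a 4.8-fold higher number from compound 2 to compound 4 (0.68 log units; beyond the scatter) and a 6.9-fold higher number from compound 1 to compound 4 (0.84 log units; beyond the scatter) as the first steps at this position beyond the scatter. The position is therefore not indifferent to its substituent, and a ring as such does not account for the weaker inhibition, since compound 1 also carries one there. No measurement at hand accounts for these steps. Open, on these data alone, is whether the number follows ring size, as cyclobutyl or cyclohexyl on this nitrogen would show. Also open, as far as these compounds go, is whether an amine or a hydroxyl on the cyclopentyl ring changes it.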